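The source may hold more compounds than are shown below. What is called first, only, known or untested is meant among the compounds shown, and "the series" means these compounds.

In a functional assay on KB cells (Homo sapiens) for inhibition (on this read-out lower numbers stand for stronger inhibition and higher numbers for weaker inhibition), compound 1 `Nc1nc2cc(Cl)c(Cl)cc2n1Cc1ccc(Cl)cc1` gives 45000 nM, level with compound 3 `Nc1nc2cc(Cl)c(Cl)cc2n1Cc1cccc(C(F)(F)F)c1` at 45000 nM. Compound 2 `Nc1nc2cc(Cl)c(Cl)cc2n1Cc1ccc(Cl)c(Cl)c1` gives 35000 nM, within the scatter of compound 1. No measured neighbour therefore stands clearly apart from compound 1.

The next change leads to compound 4 `Nc1nc2cc(Cl)c(Cl)cc2n1Cc1ccc([N+](=O)[O-])cc1` and is counted as nitro in place of chloro on an aromatic carbon. In words, this is nitro in place of chloro on an aromatic carbon, para to a large group.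

Within the data shown here, one measured step bears on it: a 1.3-fold lower number from compound 1 to compound 2 (0.11 log units; within the scatter), with chloro in place of hydrogen on an aromatic carbon, and it stays within the scatter. Compound 3 adds a second reference, carrying trifluoromethyl on the shared core and showing 45000 nM. Among the measured compounds shown here, no measured compound carries nitro, and no measured step removes chloro from the position that changes here, so the direct effect of this swap is unknown.

The expectation rests on the small step to compound 2 at 35000 nM and on the matching number of compound 3 at 45000 nM. No step beyond the scatter is expected in this assay, and no firm direction can be assigned. The estimated step is a 1.1-fold lower number from compound 1 to compound 4 (0.05 log units; within the scatter). For compound 4 the expected value is 40000 nM, with an estimated range of 15000 nM to 90000 nM.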

Compound 4, half-maximal inhibitory concentration: 35000 nM
The estimate for compound 4 lay 1.1-fold (0.06 log units) above the measured number; low and high end bracket the measured number.
By their numbers in this assay, from the lowest: compounds 2, 4, 1 and 3 (each within the scatter of the next).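

In this assay, nitro in place of chloro on an aromatic carbon, para to a large group, gives a 1.3-fold lower number from compound 1 to compound 4 (0.11 log units; within the scatter). Among these compounds, the earlier step added chloro while keeping the chloro at this position, so this is the first step that removes that atom, and a group with more heavy atoms and with hydrogen-bond acceptors leaves the number within the scatter. Chloro at this position is therefore not required to hold the read-out at the level of compound 1, although nothing measured explains why the swap makes so little difference.

As far as these compounds go, it remains open whether any group at this position can move the number beyond the scatter, for instance an amine, a carboxylic acid, or plain hydrogen in place of chloro. The compounds shown also vary only the benzyl-side ring substituents, so it is unclear whether changes on the shared core, such as replacing its amine or its two chloro groups with a longer alkyl chain, would have a larger effect than any step seen so far.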